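The compounds below may be only part of what the source reports. "The series", "measured", "known", "first", "only" and "open" are said of these compounds alone.

For the measured compounds named here, compound 2 `CC(=O)N1N=C(c2ccc(-n3ccnc3)cc2)CC1c1ccc(N(C)C)cc1` is one of two compounds measured in a functional assay on NCI-H1975 cells (Homo sapiens) for inhibition, read by sulforhodamine B assay, tested at 10 uM; on this read-out higher numbers stand for more inhibition at the one concentration tested (going by the name of the read-out) and lower numbers for less inhibition. In this assay compound 2 gives -2.1%. Going by the values given here, its companion compound 1 `CC(=O)N1N=C(c2ccc(N3CCN(C)CC3)cc2)CC1c1ccc(N(C)C)cc1` gives -1.9% in this assay, and the single step on record, a number 0.2 percentage points lower from compound 1 to compound 2 (within the scatter), shows that these two numbers cannot be told apart; both sit at the level of no inhibition. Compound 3 `C=C(C)C(=O)N1N=C(c2ccc(-n3ccnc3)cc2)CC1c1ccc(N(C)C)cc1` differs from compound 2 at another place entirely: 1-methylethenyl in place of methyl on a carbonyl carbon. Among the compounds with values here, no measured step touches the carbonyl carbon, so the step from compound 1 to compound 2 says nothing direct about this change, and the expectation rests only on the two measured values, which both lie at zero. The step of a number 7.1 percentage points higher from compound 2 to compound 3 (within the scatter) is therefore expected to stay within the scatter, with any movement uncertain. Compound 3 is estimated to give 5% in this assay, within -12% to 30%.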

Compound 3, a percentage reported as inhibition, at one concentration (the size of the read-out at that concentration, not a potency): -3.7%
For compound 3 the middle estimate is 8.7 percentage points above the measured one; the measured number falls inside the stated range.
By their numbers in this assay, from the lowest: compounds 3, 2 and 1 (each within the scatter of the next).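

For the compounds shown here, this is the first measured change at the carbonyl carbon, which bears the amide-type nitrogen in a ring. In this assay, putting 1-methylethenyl in place of methyl gives a number 1.6 percentage points lower from compound 2 to compound 3 (within the scatter), so adding this group and its double bond outside aromatic rings produces no readable effect, and the number stays at the level of no inhibition. Nothing offered here explains this result.

Still open, from the compounds shown here alone, is whether another group on this carbonyl carbon, such as aminomethyl or a longer chain such as butyl, would lift the number clear of the scatter. Also open, going by these compounds, is whether 1-methylethenyl would read the same with 4-methylpiperazin-1-yl in place of 1H-imidazol-1-yl on the aromatic carbon.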